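Series notes: ring swap on the shared core

A few compounds are considered here, and "the series" means these few. Any claim that something is new, unique, unknown or untested is made for them only; others in the source may bear on it.

For the measured compounds named here, compound 3 `O=C(c1ccc(-c2ccc3ncc(-c4cnc5ccccc5c4)n3c2)cc1)N1CCOCC1` gives 154 nM in an assay on Sf21 cells for inhibition of MAP kinase-interacting serine/threonine-protein kinase 1 (Homo sapiens), read by luminescence and ADP-Glo, with stated times of 10 min and 40 min (on this read-out higher numbers stand for weaker inhibition and lower numbers for stronger inhibition), the highest of the three numbers measured so far; compound 2 `N[C@H]1CCCN(C(=O)c2ccc(-c3ccc4ncc(-c5ccc6cnccc6c5)n4c3)cc2)C1` gives 2.5 nM and compound 1 `O=C(c1ccc(-c2ccc3ncc(-c4ccc5cnccc5c4)n3c2)cc1)N1CCC(N2CCCCC2)CC1` gives 2.4 nM, both lower by margins beyond the scatter. Compound 4 `O=C(c1ccc(-c2ccc3ncc(-c4ccc5cnccc5c4)n3c2)cc1)N1CCOCC1` is not yet measured. It differs from compound 3 only as isoquinolin-6-yl in place of quinolin-3-yl on an aromatic carbon; the rest of the two structures is the same. Among the measured compounds, compound 1 and compound 2 carry the same isoquinolin-6-yl group that enters in compound 4 and differ from each other only at the carbonyl carbon, where a 1.0-fold higher number from compound 1 to compound 2 (0.02 log units; within the scatter). Going by the values given here, no measured step exchanges quinolin-3-yl for isoquinolin-6-yl, so the size of that exchange is not known directly; what the numbers show is that both isoquinolin-6-yl compounds sit far below compound 3 in this assay, while the group on the carbonyl made no step beyond the scatter. The expected step of a 31-fold lower number from compound 3 to compound 4 (1.49 log units; beyond the scatter) is therefore downward and well beyond the scatter. The estimate for compound 4 in this assay is 5 nM, with a range from 1.5 nM to 30 nM.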

Compound 4, half-maximal inhibitory concentration: 7 nM
Beside the measured number, compound 4's estimate is 1.4-fold (0.15 log units) below it, and the stated range covers the measured number.
By their numbers in this assay, from the lowest: compounds 1 and 2 (each within the scatter of the next); then compound 4; then compound 3.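

Working notes: in this assay the exchange on the aromatic carbon of the five-membered ring now has a direct reading, a 22-fold lower number from compound 3 to compound 4 (1.34 log units; beyond the scatter) with morpholin-4-yl held on the carbonyl, although the two groups carry the same atoms, joined differently. The group on the carbonyl carbon, which had made no step beyond the scatter, now does so with morpholin-4-yl, giving a 2.8-fold higher number from compound 2 to compound 4 (0.45 log units; beyond the scatter) and a 2.9-fold higher number from compound 1 to compound 4 (0.46 log units; beyond the scatter) as modest steps beside the large ring exchange. Nothing at hand bears on why these steps take the sizes they do.

Open, as far as these compounds go, is whether the ring exchange keeps its size with an amine on the carbonyl side, as quinolin-3-yl appears here only with morpholin-4-yl. Also open, from the compounds shown here alone, is how quinolin-6-yl or naphthalen-2-yl would read on the same aromatic carbon.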